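This account rests on a few compounds, and the source may have more. Where it says the series, first, only, none or still open, it means among the compounds named here.

In a functional assay on U-373MG ATCC cells (Homo sapiens) for inhibition, read by MTT assay, with a stated time of 72 h (on this read-out lower numbers stand for stronger inhibition of growth and higher numbers for weaker inhibition of growth), the measured compounds read:
compound 1 `Cc1cn([C@@H]2O[C@H](CO[Si](c3ccccc3)(c3ccccc3)C(C)(C)C)[C@@H](O)[C@H]2O)c(=O)[nH]c1=O` at 25000 nM
compound 2 `CC(C)(C)[Si](OC[C@H]1O[C@@H](n2cnc3c(N)ncnc32)[C@H](O)[C@@H]1O)(c1ccccc1)c1ccccc1` at 44000 nM
compound 3 `CC(=O)O[C@@H]1[C@H](OC(C)=O)[C@@H](CO[Si](c2ccccc2)(c2ccccc2)C(C)(C)C)O[C@H]1n1ccc(=O)[nH]c1=O` at 32000 nM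

Compound 3 at 32000 nM lies within the scatter of both compound 1 and compound 2, so the numbers give no order among the three.

Compound 4 `CC(=O)O[C@@H]1[C@H](OC(C)=O)[C@@H](CO[Si](c2ccccc2)(c2ccccc2)C(C)(C)C)O[C@H]1n1ccc(=O)n(C(=O)c2ccccc2)c1=O` carries benzoyl in place of hydrogen on an aromatic nitrogen of compound 3 (benzoyl in place of hydrogen on an aromatic nitrogen). For the measured compounds named here, no measured compound carries benzoyl, so no measured step shows this change directly. Going by the values given here, the one measured step bears on it only loosely: a 1.8-fold higher number from compound 1 to compound 2 (0.25 log units; within the scatter) replaces a whole group on a saturated ring carbon, not a hydrogen on this nitrogen. That replacement stayed within the scatter, which gives no reason to expect a large shift here, though it cannot rule one out. In this assay the expected step is a 1.3-fold lower number from compound 3 to compound 4 (0.11 log units; within the scatter) and no firm direction is expected. Compound 4 is estimated at 25000 nM with 10000 nM to 60000 nM as the expected range.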

Compound 4, concentration for 50% growth inhibition: 26000 nM
Compound 4: middle estimate off by 1.0-fold (0.02 log units), on the low side, and the stated range covers the measured number.
By their numbers in this assay, from the lowest: compounds 1, 4, 3 and 2 (each within the scatter of the next).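

In this assay, benzoyl in place of hydrogen on the aromatic nitrogen gives a 1.2-fold lower number from compound 3 to compound 4 (0.09 log units; within the scatter), so this nitrogen of compound 3 takes up benzoyl with no step beyond the scatter. For the compounds shown here, this is the first reading at this position, since the earlier step concerned a saturated ring carbon, and it shows that this exchange leaves the number within the scatter of its parent. No supporting measurement bears on this step.

Going by these compounds, whether a methyl group, or a longer chain ending in an amine or a carboxylic acid, would read the same on this nitrogen remains open. Also open, on these data alone, is whether benzoyl on this nitrogen would read alike with free hydroxyl groups in place of the two acetyl esters.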